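Benzyl-substituted ribosides: from compound 3 to compound 4

A few compounds are considered here, and "the series" means these few. Any claim that something is new, unique, unknown or untested is made for them only; others in the source may bear on it.

Measured in a functional assay on HOS cells (Homo sapiens) for antiproliferative activity, with a stated time of 72 h; on this read-out higher numbers stand for weaker inhibition and lower numbers for stronger inhibition:
- Compound 1 `OC[C@H]1O[C@@H](n2cnc3c(NCc4cccc(F)c4)ncnc32)[C@H](O)[C@@H]1O` gives > 166000 nM as a limit
- Compound 2 `Cc1cccc(CNc2ncnc3c2ncn3[C@@H]2O[C@H](CO)[C@@H](O)[C@H]2O)c1` gives > 166000 nM as a limit
- Compound 3 `COc1cc(CNc2ncnc3c2ncn3[C@@H]2O[C@H](CO)[C@@H](O)[C@H]2O)cc(OC)c1` gives "not determined" (no result reported)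

Compound 3 has no single number to start from, and its entry in this assay remains "not determined" (no result reported). The nearest evidence is the limit of > 166000 nM in this assay, at which 2 of the 3 values shown sit.

The next compound is compound 4 `OC[C@H]1O[C@@H](n2cnc3c(NCc4cccc(O)c4O)ncnc32)[C@H](O)[C@@H]1O`, with 2,3-dihydroxyphenyl in place of 3,5-dimethoxyphenyl on a saturated chain carbon bound to a nitrogen on an aromatic ring.

Among the compounds with values here, only one measured step bears on this change, and that only loosely: a step that the two limits leave unreadable from compound 1 to compound 2. It involves a different substitution and gives no size to carry over. With no number for compound 3, no step size can be expected for this change in this assay. The expectation rests instead on the level of the measured neighbours. Compound 1 gives > 166000 nM, which is a limit. Compound 2 gives > 166000 nM, which is also a limit. A result close to that level is therefore expected, with any departure expected towards stronger inhibition, and a report of only a limit would fit equally well.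

For compound 4 the estimated value is 90000 nM, with an expected range of 15000 nM to 166000 nM.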

Compound 4, half-maximal inhibitory concentration: > 166000 nM
Compound 4 gave a limit, no number; the forecaster's own chance of this, stated with the estimate: 55%; at least 1.8-fold (0.26 log units) between middle value and limit.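

In this assay compound 4 gives > 166000 nM, a limit and not a number. No new step can be read from compound 1 or compound 2 to compound 4: all three entries are limits. The compounds shown leave open how far any of these substituents lies from the common level: the limit of > 166000 nM in this assay, at which 3 of the 4 values shown sit.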